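The compounds below may be only part of what the source reports. "The series", "measured", "known", "first", "only" and "open" are said of these compounds alone.

Of the compounds shown here, three have numbers so far. In a functional assay on L1210 cells (Mus musculus) for inhibition (on this read-out higher numbers stand for weaker inhibition and lower numbers for stronger inhibition), compound 1 (`Cc1ccc(/C=C2\CCc3ccccc3C2=O)cc1`) reads 161000 nM and compound 2 (`O=C1CCCCC/C1=C\c1ccccc1`) reads 261000 nM while compound 3 (`O=C1CCCCC/C1=C\c1ccc(F)cc1`) reads 291000 nM on the same scale. Compound 3 lies within the usual scatter of both other compounds, so these numbers cannot rank the three against one another.

The next compound is compound 4 (`O=C1CCCCC/C1=C\c1ccc(Br)cc1`), which keeps the shared core of compound 3 and alters a single group. The change is bromo in place of fluoro on an aromatic carbon. Within the data shown here, one measured step bears on it, namely fluoro in place of hydrogen on an aromatic carbon. That step is a 1.1-fold higher number from compound 2 to compound 3 (0.05 log units; within the scatter) and shows that swapping this one group made no difference beyond the scatter. Among the measured compounds shown here, no bromo compound has been measured yet, so this single small step is a thin guide.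

On that basis, the expected step in this assay is a 1.3-fold lower number from compound 3 to compound 4 (0.10 log units; within the scatter) and is estimated to stay within the scatter, with no firm direction. The estimated value for compound 4 is 230000 nM with an expected range of 120000 nM to 440000 nM as the likely span.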

Compound 4, half-maximal inhibitory concentration: 68400 nM
Estimate against measurement, compound 4: 3.4-fold (0.53 log units) above, outside the stated range (below it).
By their numbers in this assay, from the lowest: compound 4; then compounds 1, 2 and 3 (each within the scatter of the next).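

In this assay, among these compounds, this position on the aromatic ring turns out to respond to the choice of group: bromo in place of fluoro gives a 4.3-fold lower number from compound 3 to compound 4 (0.63 log units; beyond the scatter) and is the first change here to clear the scatter, which the earlier swap of hydrogen for fluoro did not do. Bromo also stands apart from plain hydrogen at the same carbon, with a 3.8-fold lower number from compound 2 to compound 4 (0.58 log units; beyond the scatter) on record, so the stronger inhibition of compound 4 reflects something particular to bromo rather than to the mere presence of a group at this carbon, since fluoro there did not separate from hydrogen. Nothing available explains why bromo and fluoro part ways at this position.

Two single atoms at one carbon cannot show what it is about bromo that matters, and a chloro or iodo group at that carbon would show whether the read-out moves steadily along that series or whether bromo is a lone case. A methoxy group or an amine in the same place would test whether anything other than a single atom is tolerated there.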